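Swapping an Aryl Arm for Vinyl on the Disulfide Side

This account rests on a few compounds, and the source may have more. Where it says the series, first, only, none or still open, it means among the compounds named here.

Compound 1 `COc1ccc(CSSC=CC[S+]([O-])Cc2ccc(OC)cc2)cc1` was measured in a functional assay on WHCO1 cells (Homo sapiens) for antiproliferative activity, read by MTT assay, with a stated time of 48 h (a higher number here means a weaker inhibitor, a lower number a stronger inhibitor), and gave 2100 nM. Among the measured compounds shown here, that is the lowest of the two numbers recorded so far; its only neighbour, compound 2 `C=CCSS/C=C\C[S+]([O-])CCCOCc1ccc(OC)cc1`, gives 21000 nM in this assay, a markedly higher figure that sits well beyond the scatter of the method. For the measured compounds named here, the two structures differ in more than one place, so the comparison says only that compound 1 is the stronger inhibitor of the pair.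

Compound 3 `C=CCSSC=CC[S+]([O-])Cc1ccc(OC)cc1` has not yet been measured. It differs from compound 1 in a single place: vinyl in place of 4-methoxyphenyl on a saturated chain carbon bound to a sulfur. The rest of the molecule, including the sulfoxide arm with its own 4-methoxyphenyl group, is retained.

Going by the values given here, no single-change step between measured compounds is available to anchor the size of this move. Because compound 2 gives 21000 nM while compound 1 gives 2100 nM, and compound 3 lies structurally between them, the writer expects a step of a 2.6-fold higher number from compound 1 to compound 3 (0.42 log units; beyond the scatter) toward a weaker inhibitor, beyond the scatter. For compound 3 the estimate is 5500 nM, with a range from 2000 nM to 15000 nM.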

Compound 3, half-maximal inhibitory concentration: 7400 nM
Compound 3: middle estimate off by 1.3-fold (0.13 log units), on the low side; the range from low to high includes it.
By their numbers in this assay, from the lowest: compound 1; then compound 3; then compound 2.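

With vinyl in place of 4-methoxyphenyl on a saturated chain carbon bound to a sulfur, the series gains its first single-change step in this assay, and that step is a 3.5-fold higher number from compound 1 to compound 3 (0.55 log units; beyond the scatter) toward a weaker inhibitor, so this place in the molecule does register the change. The step is modest, and the loss of the whole aromatic ring still leaves compound 3 with a measurable value of 7400 nM in this assay, so the 4-methoxyphenyl group at this place adds to the activity of compound 1 without being required for a measurable effect. The swap changes the ring, the hydrogen-bond acceptor and the heavy-atom count all at once, and nothing measured here shows which of these differences accounts for the step.

The compounds shown leave open whether an unsubstituted phenyl or a plain propyl chain at this place would give a value closer to that of compound 1 or to that of compound 3. They also leave open what an aryl group carrying an amine or a carboxylic acid would do here.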